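The compounds below may be only part of what the source reports. "The series", "measured", "known", "first", "only" and "open" are said of these compounds alone.

Compound 2 `CCCCN(O)C(=O)Nc1cc([C@@H]2CC[C@@H](c3cc(OC)c(OC)c(OC)c3)O2)cc(OC)c1OCCSc1ccc(Cl)cc1` stands highest of the two compounds measured in a functional assay on the whole organism for inhibition, with Mus musculus as the target, at a dose of 3 mg/kg (on this read-out lower numbers stand for less inhibition and higher numbers for more inhibition at the one dose given (going by the name of the read-out)), where compound 2 gives 43%. Within the data shown here, its only neighbour is compound 1 `CCCCN(O)C(=O)Nc1cc([C@@H]2CC[C@@H](c3cc(OC)c(OC)c(OC)c3)O2)cc(OC)c1OCCSc1ccc(Br)cc1`, which in this assay gives 11%; the one measured step is a number 32 percentage points higher from compound 1 to compound 2 (beyond the scatter), a swap of chloro for bromo at the same place on the ring. Compound 3 `CCCCN(O)C(=O)Nc1cc([C@@H]2CC[C@@H](c3cc(OC)c(OC)c(OC)c3)O2)cc(OC)c1OCCSc1cccc(Br)c1` has not been measured. The change from compound 2 is 3-bromophenyl in place of 4-chlorophenyl on a sulfur. That step bears on the halogen, since bromine comes back, but nothing measured covers the shift of the halogen to another place on the ring. A drop is therefore expected for compound 3, because the bromo compound 1 gave 11%, but with wide uncertainty; the expected step is a number 21 percentage points lower from compound 2 to compound 3 (beyond the scatter). Compound 3 is estimated at 22%, between 0% and 48%.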

Compound 3, a percentage reported as inhibition, in the whole organism at one dose (the size of the read-out at that dose, not a potency): 28%
Compound 3: the middle estimate sits 6 percentage points below what was measured; the range from low to high includes it.
By their numbers in this assay, from the lowest: compound 1; then compound 3; then compound 2.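

In this assay, keeping bromine and changing only its place, from 4-bromophenyl to 3-bromophenyl on the sulfur, gives a number 17 percentage points higher from compound 1 to compound 3 (beyond the scatter), so the place of the halogen matters as well as its identity. The other step, a number 15 percentage points lower from compound 2 to compound 3 (beyond the scatter), shows that this change does not bring the 3-bromophenyl compound up to the 4-chlorophenyl compound, although that comparison changes both the halogen and its place at once. Nothing available explains either step.

The compounds shown leave open what 3-chlorophenyl would give, which would separate the effect of chlorine from that of its place on the ring. They also leave open how a ring without a halogen, such as plain phenyl or 4-methoxyphenyl, would behave on the same sulfur.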